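Trimming tert-butyl to isopropyl on compound 2

The compounds below may be only part of what the source reports. "The series", "measured", "known", "first", "only" and "open" are said of these compounds alone.

Two compounds have numbers in an ADME assay on microsomes from liver (Mus musculus, strain CD1) for metabolic stability, read by HPLC, using NADPH, with a stated time of 30 min, tested at 0.5 uM; on this read-out lower numbers stand for slow clearance and higher numbers for fast clearance. In this assay compound 1 `CC(=O)Nc1cnc2[nH]c(=O)n([C@H]3CC[C@H](C(C)C)CC3)c(=O)c2c1` gives 1.4 mL.min-1.g-1, while compound 2 `CC(C)(C)[C@H]1CC[C@H](n2c(=O)[nH]c3ncc(N)cc3c2=O)CC1` gives 0.5 mL.min-1.g-1. Compound 2 thus holds the lower of the two numbers, and the gap between them lies beyond the usual scatter. Compound 3 `CC(C)[C@H]1CC[C@H](n2c(=O)[nH]c3ncc(N)cc3c2=O)CC1` departs from compound 2 in one place: hydrogen in place of methyl on a saturated chain carbon bound to two saturated chain carbons and a saturated ring carbon. This is hydrogen in place of methyl on a saturated chain carbon bound to two saturated chain carbons and a saturated ring carbon, or tert-butyl to isopropyl. Among the compounds with values here, no measured pair shows this change alone, so the expectation in this assay is a small rise that stays within the scatter. The estimated step is a 1.4-fold higher number from compound 2 to compound 3 (0.15 log units; within the scatter). For compound 3 the expected value is 0.7 mL.min-1.g-1, with an estimated range of 0.3 mL.min-1.g-1 to 1.5 mL.min-1.g-1.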

Compound 3, intrinsic clearance in microsomes: 1.9 mL.min-1.g-1
The estimate for compound 3 lay 2.7-fold (0.43 log units) below the measured number, outside the stated range (above it).
By their numbers in this assay, from the lowest: compound 2; then compounds 1 and 3 (each within the scatter of the next).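

In this assay, within the data shown here, tert-butyl to isopropyl is the first single change that can be read at this position, and it gives a 3.8-fold higher number from compound 2 to compound 3 (0.58 log units; beyond the scatter), so the loss of one methyl here is enough to carry the number beyond the scatter. Hydrogen in place of acetyl on a nitrogen on an aromatic ring gives a 1.4-fold higher number from compound 1 to compound 3 (0.13 log units; within the scatter), so with isopropyl kept, that change does not separate the two compounds. Nothing at hand accounts for either step.

The compounds shown leave open how acetyl on that nitrogen would read alongside tert-butyl, and so whether the two changes act independently. They also leave open how an ethyl, cyclopropyl or trifluoromethyl group would stand at the place of the tert-butyl.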